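This account rests on a few compounds, and the source may have more. Where it says the series, first, only, none or still open, it means among the compounds named here.

For the measured compounds named here, in an ADME assay on microsomes from liver (Homo sapiens) for metabolic stability, with a stated time of 10 min (a lower number here means that less of the compound is left, a higher number that more of the compound is left), compound 1 `NC(=O)[C@H]1CC[C@H](C(=O)N2CC[C@](c3ccc(C(F)(C(F)(F)F)C(F)(F)F)cc3)(S(=O)(=O)c3ccc(F)cc3)C2)CC1` gives 100%, the only number available so far. Compound 2 `COC(=O)[C@H]1CC[C@H](C(=O)N2CC[C@](c3ccc(C(F)(C(F)(F)F)C(F)(F)F)cc3)(S(=O)(=O)c3ccc(F)cc3)C2)CC1` shares its core, but for compound 2 the record reads "not determined" (no result reported), so it has no place on the scale and offers no starting value.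

The next compound is compound 3 `O=C(C1CCS(=O)(=O)CC1)N1CC[C@](c2ccc(C(F)(C(F)(F)F)C(F)(F)F)cc2)(S(=O)(=O)c2ccc(F)cc2)C1`. The structural change is 1,1-dioxothian-4-yl in place of 4-(methoxycarbonyl)cyclohexyl on a carbonyl carbon.

Going by the values given here, no measured step shows what a change at this place does, and with no number for compound 2, the size of the step from it cannot be stated. Among the compounds with values here, the only guide is compound 1 at 100%, which has the same core. A result near that level is therefore expected, with a moderate fall possible.

The estimated value for compound 3 is 88%, with an expected range of 68% to 100%.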

Compound 3, percent of the compound remaining: 93%
The estimate for compound 3 lay 5 percentage points below the measured number, within the range that was stated.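

In this assay, for the compounds shown here, the first step that can be read at this position, 1,1-dioxothian-4-yl in place of 4-carbamoylcyclohexyl on a carbonyl carbon, gives a number 7 percentage points lower from compound 1 to compound 3 (within the scatter), so the two groups cannot be told apart in this read-out. A six-membered ring with a sulfur atom and a six-membered ring of carbon only thus read alike at this place, while the step involving compound 2 cannot be read, as compound 2 has no number. Nothing measured here offers an explanation for this result.

Still open, on these data alone, is how a different kind of group at this place would read, such as a piperidin-4-yl ring with its amine, a 4-carboxycyclohexyl or an open alkyl chain. Also open, as far as these compounds go, is what a change elsewhere would do; all three compounds carry the shared core unchanged.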